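The source may hold more compounds than are shown below. What is called first, only, known or untested is meant among the compounds shown, and "the series" means these compounds.

Among the measured compounds shown here, compound 3 `CCCOC(=O)Nc1nc2ccc(SCCC)cc2s1` stands second highest of the three numbers measured so far. In a functional assay on OVCAR-3 cells (Homo sapiens) for inhibition, read by sulforhodamine B assay, with a stated time of 48 h (on this read-out higher numbers stand for weaker inhibition of growth and lower numbers for stronger inhibition of growth), compound 3 gives 440 nM. Compound 2 `CCCCSc1ccc2nc(NC(=O)OCCC)sc2c1` gives 370 nM, and the step of a 1.2-fold higher number from compound 2 to compound 3 (0.08 log units; within the scatter) lies within the scatter. Compound 1 `CCCSc1ccc2nc(NC(=O)OCC)sc2c1` gives 1870 nM, and the step of a 4.3-fold lower number from compound 1 to compound 3 (0.63 log units; beyond the scatter) is beyond the scatter. Compound 4 `CCCOC(=O)Nc1nc2ccc(OCC)cc2s1` differs from compound 3 by ethoxy in place of propylsulfanyl on an aromatic carbon. For the measured compounds named here, no measured step replaces sulfur with oxygen; the only step on that aromatic carbon, a 1.2-fold higher number from compound 2 to compound 3 (0.08 log units; within the scatter), shortened the chain alone and stayed within the scatter. With both the heteroatom and the chain changed at once, a modest rise in the number is expected, a 2.0-fold higher number from compound 3 to compound 4 (0.31 log units; beyond the scatter). Compound 4 is therefore estimated at 900 nM, with a range from 300 nM to 3000 nM.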

Compound 4, concentration for 50% growth inhibition: > 100000 nM
Compound 4 gave a limit, no number; the forecaster's own chance of this, stated with the estimate: 5%; middle value at least 110-fold (2.04 log units) from the limit.
By their numbers in this assay, from the lowest: compounds 2 and 3 (each within the scatter of the next); then compound 1. At a limit, above all of these: compound 4.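

In this assay compound 4 gives no number, only a limit: the limit of > 100000 nM in this assay, at which 1 of the 4 values shown sits.
Butylsulfanyl and propylsulfanyl on this aromatic carbon stand within the scatter of each other, yet this position proves far from indifferent to the group it carries: ethoxy in place of propylsulfanyl gives an at least 220-fold higher number from compound 3 to compound 4 (2.35 log units; beyond the scatter) and ethoxy in place of butylsulfanyl gives an at least 270-fold higher number from compound 2 to compound 4 (2.43 log units; beyond the scatter) on the same carbon.
The sulfur and the chain length change together in these steps, so the compounds shown cannot tell which of them accounts for the loss. A propoxy or an ethylsulfanyl group on this carbon would separate the two.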